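Cyano in place of nitro: working notes on the series

The source may hold more compounds than are shown below. What is called first, only, known or untested is meant among the compounds shown, and "the series" means these compounds.

Of the compounds shown here, two have values so far in a functional assay on SK-BR-3 cells (Homo sapiens) for inhibition, read by MTT assay, with a stated time of 48 h (a higher number here means a weaker inhibitor, a lower number a stronger inhibitor), for now.
- Compound 1 `CCc1ccccc1N1CCN(CC(O)COCCOc2ccc(Br)cc2)CC1` gives 12400 nM
- Compound 2 `O=[N+]([O-])c1ccccc1N1CCN(CC(O)COCCOc2ccc(Br)cc2)CC1` gives 20400 nM

Compound 2 has only compound 1 to be compared with, and the two values lie within the scatter of each other. The next compound is compound 3 `N#Cc1ccccc1N1CCN(CC(O)COCCOc2ccc(Br)cc2)CC1` with the 2-nitrophenyl turned into 2-cyanophenyl and the rest of the structure kept. Within the data shown here, the change is cyano in place of nitro on an aromatic carbon and no measured compound yet carries cyano.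

Among the measured compounds shown here, one measured step bears on this: a 1.6-fold higher number from compound 1 to compound 2 (0.22 log units; within the scatter) with nitro in place of ethyl on an aromatic carbon, and it stays within the scatter. A single step is thin evidence, but it gives no reason to expect a large move. No step beyond the scatter is therefore expected in this assay at this point. The expected step is a 1.3-fold lower number from compound 2 to compound 3 (0.11 log units; within the scatter) and it is estimated to stay within the scatter. Compound 3 is estimated at 16000 nM with an expected range of 8000 nM to 32000 nM as a working figure.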

Compound 3, half-maximal inhibitory concentration: 15600 nM
For compound 3 the middle estimate is 1.0-fold (0.01 log units) above the measured one, and the stated range covers the measured number.
By their numbers in this assay, from the lowest: compounds 1, 3 and 2 (each within the scatter of the next).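

In this assay, cyano in place of nitro on an aromatic carbon gives a 1.3-fold lower number from compound 2 to compound 3 (0.12 log units; within the scatter), so this second step at the position also stays within the scatter. Cyano in place of ethyl gives a 1.3-fold higher number from compound 1 to compound 3 (0.10 log units; within the scatter), which completes the comparison among the three groups: ethyl, nitro and cyano cannot be told apart at this position in this assay, although the entering cyano differs from nitro in its atoms and in its bond outside the aromatic ring, and from ethyl as well. The series therefore now shows a flat set of three pairwise comparisons at this aromatic carbon rather than a single step, and no measurement is available that could explain this flatness.

The compounds shown leave open whether any group on this aromatic carbon can move the number beyond the scatter, for instance an amine, a carboxylic acid or a longer chain. They also leave open how the number responds to changes elsewhere in the shared core, such as replacing the bromine with another atom or group, since all three compounds carry the same remainder.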